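The source may hold more compounds than are shown below. What is called first, only, known or untested is meant among the compounds shown, and "the series" means these compounds.

Values so far in a functional assay on A549 cells (Homo sapiens) for inhibition, read by CCK-8 assay, with a stated time of 48 h; on this read-out higher numbers stand for weaker inhibition and lower numbers for stronger inhibition:
- compound 1 `COc1cc(-c2ccnc3cc(-c4cn(CO)c5ccccc45)nn23)cc(OC)c1OC` (167 nM)
- compound 2 `COc1cc(-c2ccnc3cc(-c4ccc(C)cc4)nn23)cc(OC)c1OC` (3 nM)
- compound 3 `COc1cc(-c2ccnc3cc(-c4ccccc4)nn23)cc(OC)c1OC` (208 nM)

Compound 3 (208 nM) sits within the scatter of compound 1 and far from compound 2 on the numbers. Next is compound 4 `COc1cc(-c2ccnc3cc(-c4cn(C)c5ccccc45)nn23)cc(OC)c1OC`, with the change 1-methyl-1H-indol-3-yl in place of phenyl on an aromatic carbon as 1-methyl-1H-indol-3-yl takes the place of phenyl on an aromatic carbon.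

Among the compounds with values here, the one measured single-place step, a 69-fold higher number from compound 2 to compound 3 (1.84 log units; beyond the scatter) and large, is hydrogen in place of methyl on an aromatic carbon. Within the data shown here, it is not an exchange of the whole group, so it shows only that a small change can move the number a long way. Compound 1, which also carries an indole group at this place, gives (167 nM) and so stays level with compound 3. That points to a modest change at most, though a larger one cannot be excluded. In this assay the expected step is a 2.6-fold lower number from compound 3 to compound 4 (0.41 log units; beyond the scatter) and it may prove to lie within the scatter. For compound 4 the estimated value is 80 nM with an expected range of 10 nM to 300 nM on this read-out.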

Compound 4, half-maximal inhibitory concentration: 1340 nM
For compound 4 the middle estimate is 17-fold (1.22 log units) below the measured one; the measured number lies above the stated range.
By their numbers in this assay, from the lowest: compound 2; then compounds 1 and 3 (each within the scatter of the next); then compound 4.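

In this assay, 1-methyl-1H-indol-3-yl in place of phenyl on this aromatic carbon weakens inhibition (a 6.4-fold higher number from compound 3 to compound 4 (0.81 log units; beyond the scatter)), and the gap from the 4-methylphenyl compound is far wider (a 450-fold higher number from compound 2 to compound 4 (2.65 log units; beyond the scatter)), so an indole group here does not match either phenyl group. The group on the aromatic nitrogen of the indole also matters: hydrogen in place of hydroxy on the saturated chain carbon weakens inhibition (an 8.0-fold higher number from compound 1 to compound 4 (0.90 log units; beyond the scatter)), so the level standing of compound 1 with compound 3 does not extend to compound 4. No measurement at hand accounts for these steps.

Open, as far as these compounds go, is whether a longer chain such as ethyl, or a methoxy or chloro group, can replace the methyl of the 4-methylphenyl group. Also open, from the compounds shown here alone, is how an amine or a carboxylic acid on the aromatic nitrogen of the indole group would read.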